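The compounds below may be only part of what the source reports. "The series", "measured", "known", "first", "only" and "open" are said of these compounds alone.

Working notes on the series. Compound 1 `Fc1ccc(-c2csc(N/N=C/c3ccc(Cl)cc3Cl)n2)cc1` gives 90.7% in a functional assay, read by spectrophotometry, with a stated time of 15 min, tested at 20 ug/mL; a lower number here means a weaker effect, a higher number a stronger effect of the compound at the concentration tested; compound 2 `Cc1ccc(-c2csc(N/N=C/c3ccc(Cl)cc3Cl)n2)cc1` gives 86%; compound 3 `COc1ccc(-c2csc(N/N=C/c3ccc(Cl)cc3Cl)n2)cc1` gives 65.5%, the lowest of the three numbers, with the nearest value, that of compound 2, beyond the scatter above it. The steps into compound 3 are a number 25.2 percentage points lower from compound 1 to compound 3 (beyond the scatter) and a number 20.5 percentage points lower from compound 2 to compound 3 (beyond the scatter), while a number 4.7 percentage points lower from compound 1 to compound 2 (within the scatter) lies within the scatter. Compound 4 `Clc1ccc(-c2csc(N/N=C/c3ccc(Cl)cc3Cl)n2)cc1` differs from compound 3 as follows: chloro in place of methoxy on an aromatic carbon. Both measured steps that bear on this change ran downward on going to methoxy; the change back away from methoxy is therefore expected to run upward by a modest step, a number 19.5 percentage points higher from compound 3 to compound 4 (beyond the scatter). Compound 4 is estimated at 85%, in the range 68% to 95%.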

Compound 4, a percentage reported as inhibition, at one concentration (the size of the read-out at that concentration, not a potency): 73.9%
Beside the measured number, compound 4's estimate is 11.1 percentage points above it; measured number inside the range.
By their numbers in this assay, from the lowest: compounds 3 and 4 (each within the scatter of the next); then compounds 2 and 1 (each within the scatter of the next).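

In this assay the move away from methoxy gives a number 8.4 percentage points higher from compound 3 to compound 4 (within the scatter), so chloro does not separate from methoxy at this position. The other two steps are a number 12.1 percentage points lower from compound 2 to compound 4 (beyond the scatter) and a number 16.8 percentage points lower from compound 1 to compound 4 (beyond the scatter), which set chloro apart from both methyl and fluoro, so the earlier split is not methoxy against all the other groups: compound 3 and compound 4 stand together, below compound 1 and compound 2. Nothing available accounts for this grouping. From the compounds shown here alone, whether an amine or a carboxylic acid on this aromatic carbon would fall with compound 1 and compound 2 or with compound 3 and compound 4 remains open.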